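A few compounds are considered here, and "the series" means these few. Any claim that something is new, unique, unknown or untested is made for them only; others in the source may bear on it.

Among the compounds with values here, in an ADME assay on MDCKII-LE cells (Canis lupus familiaris) for permeability (on this read-out higher numbers stand for higher permeability and lower numbers for lower permeability), compound 1 `N#CCCN([C@H](CCC(F)(F)F)C(N)=O)S(=O)(=O)c1ccc(Cl)cc1` gives 10.2 10^-6 cm/s, while compound 2 `N#C[C@H]1C[C@@H]1CN([C@H](CCC(F)(F)F)C(N)=O)S(=O)(=O)c1ccc(Cl)cc1` gives 21.5 10^-6 cm/s, the higher of the two numbers so far. Within the data shown here, the one measured step, a 2.1-fold higher number from compound 1 to compound 2 (0.32 log units; beyond the scatter), is modest, though beyond the scatter, and it exchanges one group for another. Compound 3 `N#C[C@@H]1C[C@H]1CN([C@H](CCC(F)(F)F)C(N)=O)S(=O)(=O)c1ccc(Cl)cc1` keeps the atoms and bonds of compound 2: the two compounds have the same atoms and bonds and differ only in configuration as drawn: 2 of 3 stereo elements differ; a stereocentre at a saturated ring carbon is drawn S in compound 2 and R in compound 3; a stereocentre at a saturated ring carbon is drawn S in compound 2 and R in compound 3. Among the measured compounds shown here, no measured step tests a change of configuration alone, so no clear direction can be drawn, and no shift beyond the scatter is expected in this assay. The expected step is a 1.1-fold lower number from compound 2 to compound 3 (0.03 log units; within the scatter). Compound 3 is estimated at 20 10^-6 cm/s, with an expected range of 10 10^-6 cm/s to 38 10^-6 cm/s.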

Compound 3, apparent permeability: 9.94 10^-6 cm/s
The estimate for compound 3 lay 2.0-fold (0.30 log units) above the measured number, outside the stated range (below it).
By their numbers in this assay, from the lowest: compounds 3 and 1 (each within the scatter of the next); then compound 2.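

Compound 2 and compound 3 show that the drawn configuration of the ring matters in this assay. The step is a 2.2-fold lower number from compound 2 to compound 3 (0.34 log units; beyond the scatter), and it can only come from configuration, because of this: the fact that compounds 2 and 3 differ only in the configuration as drawn The 2-cyanocyclopropyl group in place of cyanomethyl therefore does not set the number by itself, since with the other configuration the change gives a 1.0-fold lower number from compound 1 to compound 3 (0.01 log units; within the scatter).

The compounds shown leave open how the remaining configurations of the two ring stereocentres would read. They also leave open whether a carboxylic acid or an amine in place of the nitrile would depend on configuration in the same way.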